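Swapping Dimethylamino for Fluoro: What to Expect from Compound 4

The source may report more compounds than this note shows. Statements on the series, on what has been measured and on what is new or still open speak of the compounds shown alone.

Of the compounds shown here, three on one shared core have been tested in a functional assay on HT-29 cells (Homo sapiens) for inhibition, read by sulforhodamine B assay, with a stated time of 48 h; on this read-out lower numbers stand for stronger inhibition of growth and higher numbers for weaker inhibition of growth. Compound 1 `COc1ccc(/C=N/NC(=S)NC(C)(C)[C@H]2CC=C(C)CC2)cc1` carries a methoxy group on its aromatic ring, and in this assay compound 1 gives 33600 nM. Compound 2 `CC1=CC[C@H](C(C)(C)NC(=S)N/N=C/c2ccc(O)cc2)CC1` bears a hydroxy group there instead. In this assay compound 2 reaches only the limit of the assay, > 100000 nM. Compound 3 `CC1=CC[C@H](C(C)(C)NC(=S)N/N=C/c2ccc(N(C)C)cc2)CC1` carries a dimethylamino group. In this assay compound 3 likewise sits at the limit, > 100000 nM. Compound 3 therefore stands at the top of the numbers shown, together with compound 2, as recorded in the limit of > 100000 nM in this assay, at which 2 of the 3 values shown sit; the step of an at least 2.9-fold higher number from compound 1 to compound 3 (0.47 log units; beyond the scatter) leads to it, while the step that the two limits leave unreadable from compound 2 to compound 3 cannot be sized.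

Compound 4 `CC1=CC[C@H](C(C)(C)NC(=S)N/N=C/c2ccc(F)cc2)CC1` differs from compound 3 by fluoro in place of dimethylamino on an aromatic carbon. For the measured compounds named here, no measured step exchanges dimethylamino for fluoro, so the only guidance comes from the steps away from the methoxy of compound 1: an at least 2.9-fold higher number from compound 1 to compound 2 (0.47 log units; beyond the scatter) and an at least 2.9-fold higher number from compound 1 to compound 3 (0.47 log units; beyond the scatter) both moved beyond the scatter toward the limit. Whether fluoro behaves like the methoxy of compound 1 or like the groups of compounds 2 and 3 is not shown. Compound 4 is expected to give 70000 nM, between 25000 nM and 200000 nM. That estimate means an expected step of an at least 1.4-fold lower number from compound 3 to compound 4 (0.15 log units; that floor lies within the scatter).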

Compound 4, concentration for total growth inhibition: > 100000 nM
Compound 4 gave a limit, no number; the forecaster's own chance of this, stated with the estimate: 45%; middle value at least 1.4-fold (0.15 log units) from the limit.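

With fluoro in place, compound 4 joins compound 2 and compound 3 at the limit, so three different groups at this place on the aromatic ring, para to a large group, now end there in this assay, and only the methoxy of compound 1 gives a number: the limit of > 100000 nM in this assay, at which 3 of the 4 values shown sit.

Replacing methoxy with fluoro gives an at least 2.9-fold higher number from compound 1 to compound 4 (0.47 log units; beyond the scatter), the third change away from methoxy to move in this direction, and here the entering group is a lone fluorine atom rather than the hydroxy or dimethylamino seen earlier. The steps from compound 2 and from compound 3 to compound 4 cannot be read, as both ends of each are limits, so nothing places hydroxy, dimethylamino and fluoro in any order among themselves.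

The compounds shown leave open whether methoxy is alone at this place in giving a number, or whether an ethoxy group, a longer alkoxy chain or a methyl group would also give one. They also leave open how far below the limit any such group could reach on the shared core.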